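The source may report more compounds than this note shows. Statements on the series, on what has been measured and on what is new or still open speak of the compounds shown alone.

Compound 1 `CN(C)C1CCc2cc(N3CC[C@H](NS(=O)(=O)/C=C/c4ccc(Cl)s4)C3=O)ccc21`: 1.1 L/kg
Compound 2 `CN(C)[C@H]1CCc2cc(N3CC[C@H](NS(=O)(=O)c4ccc5cc(Cl)ccc5c4)C3=O)ccc21`: 2 L/kg

Both compounds were measured in an in vivo ADME assay on the whole organism (strain Sprague-Dawley) for pharmacokinetics, with Rattus norvegicus as the target; on this read-out higher numbers stand for wider distribution into tissues and lower numbers for narrower distribution. Compound 2 gives 2 L/kg, and this lies within the usual scatter of the value for compound 1, 1.1 L/kg, so the two stand level on this read-out. Among the compounds with values here, they also differ in more than one place, and no measured pair here isolates a single structural change.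

The next compound is compound 3 `CN(C)[C@@H]1CCc2cc(N3CC[C@H](NS(=O)(=O)c4ccc5cc(Cl)ccc5c4)C3=O)ccc21`, which is compared with compound 2. The change is this: the two compounds have the same atoms and bonds and differ only in configuration as drawn: 1 of 2 stereo elements differ; a stereocentre at a saturated ring carbon is drawn S in compound 2 and R in compound 3. Nothing leaves and nothing enters, and only the configuration at that saturated ring carbon differs.

Within the data shown here, no measured pair shows what such a change does to this assay, so any expectation is an anchored guess. The best starting point is compound 2 at 2 L/kg, and no shift beyond the scatter is expected, in either direction. The estimated step of a 1.1-fold lower number from compound 2 to compound 3 (0.05 log units; within the scatter) is correspondingly small. For compound 3 the expected value is 1.8 L/kg, with an estimated range from 0.9 L/kg to 3.6 L/kg.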

Compound 3, volume of distribution at steady state: 1.7 L/kg
Estimate against measurement, compound 3: 1.1-fold (0.02 log units) above; the range from low to high includes it.
By their numbers in this assay, from the lowest: compounds 1, 3 and 2 (each within the scatter of the next).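

In this assay, within the data shown here, this pair gives the first reading of a single structural change: inverting the saturated ring carbon gives a 1.2-fold lower number from compound 2 to compound 3 (0.07 log units; within the scatter), and the two forms stand level. At this position, then, the configuration as drawn, S or R, makes no difference beyond the scatter to how widely these compounds distribute in the rat, something the earlier pair, which differed in more than one place, could not show. The reading can be assigned to this one stereocentre alone: the fact that compounds 2 and 3 differ only in the configuration as drawn

Still open, as far as these compounds go, is what the other stereo element, drawn alike in compound 2 and compound 3, contributes in this assay. Also open, from the compounds shown here alone, is how the number would respond if a primary amine or a carboxylic acid stood at that saturated ring carbon in place of the group it now carries, and whether the configuration there would then matter any more than it does here.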